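Aryl swap on the shared core and Vero cell cytotoxicity

The source may report more compounds than this note shows. Statements on the series, on what has been measured and on what is new or still open speak of the compounds shown alone.

Of the compounds shown here, two have so far been measured in an ADME assay on Vero cells (Chlorocebus sabaeus) for cytotoxicity, with a stated time of 72 h; a lower number here means a stronger inhibitor, a higher number a weaker inhibitor. Compound 1 `Cc1nonc1C(=O)NC1CCCc2c1cnn2-c1ccc(C(F)(F)F)cc1` gives > 128000 nM in this assay, which is a limit of the assay and not a number. Compound 2 `CC(C)(C)c1ccc(-n2ncc3c(NC(=O)c4ccc5c(c4)no[n+]5[O-])cccc32)cc1` gives 1800 nM in this assay, the only number shown. The other value shown, for compound 1, is a limit: the limit of > 128000 nM in this assay, at which 1 of the 2 values shown sits. Compound 3 `Cc1cc(C)cc(-n2ncc3c(NC(=O)c4ccc5c(c4)no[n+]5[O-])cccc32)c1` has not been measured. It differs from compound 2 in one place: 3,5-dimethylphenyl in place of 4-(tert-butyl)phenyl on an aromatic nitrogen. Among the compounds with values here, no measured pair of compounds shows what such a swap does in this assay. The step from compound 2 to compound 3 is expected to be small, toward a weaker inhibitor if anything, a 1.7-fold higher number from compound 2 to compound 3 (0.22 log units; within the scatter), and not clearly beyond the usual scatter. Compound 3 is therefore expected to give 3000 nM in this assay, in a range from 1000 nM to 12000 nM.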

Compound 3, half-maximal inhibitory concentration: 16100 nM
Beside the measured number, compound 3's estimate is 5.4-fold (0.73 log units) below it; measured number outside the range, above it.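

The aryl group on the aromatic nitrogen is not a silent position in this assay: 3,5-dimethylphenyl in place of 4-(tert-butyl)phenyl gives an 8.9-fold higher number from compound 2 to compound 3 (0.95 log units; beyond the scatter). Within the data shown here, this is the first measured pair to show that the number can move with this swap alone, although both groups are one six-membered aromatic ring of carbon only and neither brings hydrogen-bond donors or acceptors. Nothing shown gives a reason for the step.

The swap exchanges one tert-butyl group for two methyl groups and moves the substitution on the ring, and this single step cannot separate those two changes. The compounds shown also leave open what an unsubstituted phenyl, or a phenyl carrying an amine or a carboxylic acid, would give at this position in this assay.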